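A few compounds are considered here, and "the series" means these few. Any claim that something is new, unique, unknown or untested is made for them only; others in the source may bear on it.

Among the compounds with values here, compound 2 `CC(C)(C)OC(=O)N1CCN(C(=S)SCc2cn(Cc3ccc(Cl)c(Cl)c3)nn2)CC1` gives 33700 nM in a functional assay on MGC-803 cells (Homo sapiens) for inhibition, read by MTT assay, with a stated time of 72 h (on this read-out lower numbers stand for stronger inhibition and higher numbers for weaker inhibition), the lower of the two numbers measured so far, while compound 1 `Cc1ccc(-n2cc(CSC(=S)N3CCN(C(=O)OC(C)(C)C)CC3)nn2)cc1` gives 48300 nM in this assay, and the gap between them, a 1.4-fold lower number from compound 1 to compound 2 (0.16 log units; within the scatter), lies within the scatter. Compound 3 `CC(C)(C)OC(=O)N1CCN(C(=S)SCc2cn(Cc3ccc(Cl)cc3)nn2)CC1` is compound 2 with one chloro removed: hydrogen in place of chloro on an aromatic carbon. Within the data shown here, only one measured step bears on this change, the exchange of the whole aryl group on the nitrogen, which read a 1.4-fold lower number from compound 1 to compound 2 (0.16 log units; within the scatter) and was itself within the scatter; no measured pair isolates the loss of a single chloro, and that loss is a smaller structural move than the full swap of the aryl group. On that basis no step beyond the scatter is expected for compound 3 in this assay in either direction, the expected step being a 1.2-fold higher number from compound 2 to compound 3 (0.07 log units; within the scatter). Compound 3 is therefore estimated at 40000 nM in this assay, with a range from 15000 nM to 110000 nM to cover the weak evidence.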

Compound 3, half-maximal inhibitory concentration: 9790 nM
Compound 3: middle estimate off by 4.1-fold (0.61 log units), on the high side; the whole stated range lies above it.
By their numbers in this assay, from the lowest: compound 3; then compounds 2 and 1 (each within the scatter of the next).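

In this assay, within the data shown here, the step of a 3.4-fold lower number from compound 2 to compound 3 (0.54 log units; beyond the scatter) is the first in this set to lie beyond the scatter: taking away the chloro on the aromatic carbon that is ortho to a chloro group and meta to a large group, turning 3,4-dichlorobenzyl into 4-chlorobenzyl, gives stronger inhibition. The earlier exchange of the whole group on the aromatic nitrogen had shown no step beyond the scatter, yet 4-chlorobenzyl in place of 4-methylphenyl reads a 4.9-fold lower number from compound 1 to compound 3 (0.69 log units; beyond the scatter), so this group can shift the number and a single chloro decides whether the shift appears. Nothing available accounts for this gain on losing the chloro, and it stands as an observation only.

From the compounds shown here alone, it remains open whether the gain is specific to hydrogen at this position or would also hold with a fluoro, methyl or methoxy group there. Also open, going by these compounds, is what the remaining chloro contributes, which a plain benzyl group would test, and whether a 4-chlorophenyl group directly on the nitrogen would read like 4-chlorobenzyl.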